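Chalcone anilide series: bromo replaced by 4-acetylphenoxy

A few compounds are considered here, and "the series" means these few. Any claim that something is new, unique, unknown or untested is made for them only; others in the source may bear on it.

Three members of the series carry a measured number in a functional assay on the whole organism (strain albino) for inhibition, with Rattus norvegicus as the target, read by paw edema, with stated times of 30 min and 1 h, at a dose of 100 mg/kg by the oral route; on this read-out higher numbers stand for more inhibition at the one dose given (going by the name of the read-out) and lower numbers for less inhibition. Compound 1 `O=C(CBr)Nc1ccc(C(=O)/C=C/c2ccc(Cl)cc2)cc1` gives 44% in this assay. Compound 2 `COc1ccc(/C=C/C(=O)c2ccc(NC(=O)CBr)cc2)cc1` gives 37% in this assay. Compound 3 `COc1ccc(/C=C/C(=O)c2ccc(NC(=O)C(C)Br)cc2)cc1` gives 39% in this assay. Compound 2 holds the lowest of the three numbers, yet both of its steps to the others sit within the scatter: the step of a number 7 percentage points lower from compound 1 to compound 2 (within the scatter) for methoxy in place of chloro on an aromatic carbon, and the step of a number 2 percentage points higher from compound 2 to compound 3 (within the scatter) for methyl in place of hydrogen on a saturated chain carbon bound to a bromine atom and a carbonyl carbon. Neither change moved the read-out beyond the scatter.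

Compound 4 `COc1ccc(/C=C/C(=O)c2ccc(NC(=O)COc3ccc(C(C)=O)cc3)cc2)cc1` is not yet measured. It differs from compound 2 by 4-acetylphenoxy in place of bromo on a saturated chain carbon bound to a carbonyl carbon. Within the data shown here, no measured step removes the bromo itself, so nothing speaks directly to this change. The nearest comparison is the step of a number 2 percentage points higher from compound 2 to compound 3 (within the scatter) at the same saturated chain carbon, and it was small. On that basis a step of a number 1 percentage points higher from compound 2 to compound 4 (within the scatter) in this assay is expected for compound 4, that is, nothing beyond the scatter. Compound 4 is therefore estimated at 38% in this assay, with a range from 24% to 52%.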

Compound 4, a percentage reported as inhibition, in the whole organism at one dose (the size of the read-out at that dose, not a potency): 28%
Beside the measured number, compound 4's estimate is 10 percentage points above it, within the range that was stated.
By their numbers in this assay, from the lowest: compounds 4, 2, 3 and 1 (each within the scatter of the next, the first and the last beyond it).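

With 4-acetylphenoxy in place of bromo on the saturated chain carbon bound to a carbonyl carbon, the series records a number 9 percentage points lower from compound 2 to compound 4 (within the scatter) in this assay. Among these compounds, this is the first step to remove the bromo, and it shows that this carbon can carry a group of 10 heavy atoms, with one six-membered aromatic ring and 2 hydrogen-bond acceptors, without the read-out leaving the scatter, so inhibition at the one dose given does not depend on the bromo in this pair. No supporting measurement bears on why the read-out behaves this way, and this single step does not separate the loss of the bromo from the gain of the new group.

On these data alone, how a smaller phenoxy without the acetyl, an amine or a carboxylic acid would read on the same carbon remains open, and any of these would help separate the two halves of the exchange. Also open, as far as these compounds go, is whether 4-acetylphenoxy gives a similar result with chloro in place of methoxy on the aromatic carbon, and at doses other than the one given.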